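The source may report more compounds than this note shows. Statements on the series, on what has been measured and on what is new or still open speak of the compounds shown alone.

Series notes, hydrazone set. Compound 1 `Cc1ccc(C(=O)N/N=C/c2cc(Cl)cc(Cl)c2O)c(O)c1` carries two chloro groups and a hydroxy group on its aldehyde-derived ring. In a functional assay (Mus musculus, strain BALB/C) for inhibition, read by MTT assay, with stated times of 24 h and 72 h (a lower number here means a stronger inhibitor, a higher number a weaker inhibitor), compound 1 gives 1510 nM. Compound 2 `Cc1ccc(C(=O)N/N=C/c2ccccc2Cl)c(O)c1` has a single chloro group and no hydroxy on that ring; in this assay compound 2 gives 19200 nM. Compound 3 `COc1ccc(/C=N/NC(=O)c2ccc(C)cc2O)cc1` carries a methoxy group instead. In this assay compound 3 reaches only a limit of the assay, > 100000 nM, and no number. Among the two numbers shown, compound 1 has the lowest; compound 2 is the nearest and its number is higher by a margin that lies beyond the scatter of this assay. One of the three values shown sits at the limit (the limit of > 100000 nM in this assay, at which 1 of the 3 values shown sits).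

Compound 4 `Cc1ccc(C(=O)N/N=C/c2cc(Cl)ccc2O)c(O)c1` has not yet been measured in this assay. The change from compound 1 to compound 4 is hydrogen in place of chloro on an aromatic carbon. Within the data shown here, no measured pair of this series differs in one place, so the size of this step cannot be read from the data; on the values of compound 1 and compound 2 the expectation is a loss of potency that is modest, possibly within the scatter.

Compound 4 is expected to give about 3500 nM in this assay, with a likely range of 1200 nM to 12000 nM. The expected step from compound 1 to compound 4 is a 2.3-fold higher number from compound 1 to compound 4 (0.37 log units; beyond the scatter).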

Compound 4, half-maximal inhibitory concentration: 1290 nM
Estimate against measurement, compound 4: 2.7-fold (0.43 log units) above, and the stated range covers the measured number.
By their numbers in this assay, from the lowest: compounds 4 and 1 (each within the scatter of the next); then compound 2. At a limit, above all of these: compound 3.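

Among these compounds, the step from chloro to hydrogen on this aromatic carbon is the first one-place change that can be read: in this assay, it is a 1.2-fold lower number from compound 1 to compound 4 (0.07 log units; within the scatter). At this place, ortho to a hydroxy group and meta to a chloro group, the chloro group of compound 1 can therefore give way to hydrogen with no change that can be told from the usual scatter, so the earlier impression that each chloro group on this ring adds potency does not hold for this one. No measured property shown bears on why the step is so small, and the single step gives no ground for a cause.

The contributions of the remaining chloro group and of the hydroxy group in compound 4 cannot be read, as no one-place step shown isolates either of them. Among the compounds shown here, also open is how far this position tolerates anything other than hydrogen or chloro, for instance an amine or a carboxylic acid, as the flat step covers only this one exchange on the core of compound 1.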